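The source may hold more compounds than are shown below. What is called first, only, known or untested is meant among the compounds shown, and "the series" means these compounds.

Measured so far in a functional assay on CHO cells for agonist activity at Free fatty acid receptor 1 (Homo sapiens), read by FLIPR and calcium flux, tested at 100 nM; on this read-out lower numbers stand for a weaker effect and higher numbers for a stronger effect at the one concentration tested:
compound 1, `Cc1nc(-c2ccc(Cl)s2)sc1COc1ccc2c(c1)OCC2CC(=O)O`: 8.34%
compound 2, `Cc1nc(-c2ccccc2C(F)(F)F)sc1COc1ccc2c(c1)OCC2CC(=O)O`: 7.76%

Compound 2 stands alongside compound 1: the step of a number 0.6 percentage points lower from compound 1 to compound 2 (within the scatter) is within the scatter, so on the numbers shown the two cannot be told apart. Going by the values given here, that step exchanges one aryl group for another on the same aromatic carbon of the shared core, and it is the only measured step that bears on the next change.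

Compound 3, `COc1ccc(-c2nc(C)c(COc3ccc4c(c3)OCC4CC(=O)O)s2)cc1`, is not yet measured. Its change from compound 2 is 4-methoxyphenyl in place of 2-(trifluoromethyl)phenyl on an aromatic carbon, again one aryl group replaced by another at that carbon. Among the compounds with values here, since the one comparable step, a number 0.6 percentage points lower from compound 1 to compound 2 (within the scatter), was within the scatter, no step beyond the scatter is expected in this assay in either direction. Compound 3 is therefore estimated at 8%, range 2% to 18%. For compound 3 the expected step is a number 0.2 percentage points higher from compound 2 to compound 3 (within the scatter).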

Compound 3, a percentage reported as activity, at one concentration (the size of the read-out at that concentration, not a potency): 46.8%
The estimate for compound 3 lay 38.8 percentage points below the measured number; measured number outside the range, above it.
By their numbers in this assay, from the lowest: compounds 2 and 1 (each within the scatter of the next); then compound 3.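

In this assay, the aromatic carbon bearing the aryl group on the five-membered ring with 1 nitrogen and 1 sulfur proves responsive to the group placed there: 4-methoxyphenyl in place of 2-(trifluoromethyl)phenyl gives a number 39 percentage points higher from compound 2 to compound 3 (beyond the scatter), and 4-methoxyphenyl in place of 5-chlorothiophen-2-yl gives a number 38.5 percentage points higher from compound 1 to compound 3 (beyond the scatter). The exchange between compound 1 and compound 2 gave no sign of this, as those two values lie within the scatter of each other. No supporting data bear on the origin of these steps.

The compounds shown leave open whether the gain follows the methoxy group itself or simply the loss of the two earlier aryl groups. A 4-(trifluoromethyl)phenyl or 2-methoxyphenyl group at this carbon would separate the identity of the substituent from its place on the phenyl ring.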